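The source may report more compounds than this note shows. Statements on the series, on what has been measured and on what is new or still open speak of the compounds shown alone.

Among the compounds with values here, compound 1, `CN(Cc1cn(CC(O)COC(=O)C2CCCCC2)nn1)CC1CCCCC1`, was tested in an assay on nucleic acid for inhibition of Nucleic Acid, read by fluorescence, tested at 100 uM (a lower number here means less inhibition, a higher number more inhibition at the concentration tested (going by the name of the read-out)), and gave 18%, the highest of the three numbers measured so far. Compound 2, `CCCCN(CCCC)Cc1cn(CC(O)COC(=O)C2CCCCC2)nn1`, gave 12%; the step of a number 6 percentage points lower from compound 1 to compound 2 (within the scatter) lies within the scatter, so the two compounds cannot be told apart. Compound 3, `CC(C)CCN(C)Cc1cn(CC(O)COC(=O)C2CCCCC2)nn1`, gave 0%, and the step of a number 18 percentage points lower from compound 1 to compound 3 (beyond the scatter) is a modest fall beyond the scatter. The step of a number 12 percentage points lower from compound 2 to compound 3 (beyond the scatter) is likewise a modest fall.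

Compound 4, `CN(Cc1cn(CC(O)COC(=O)NCc2ccccc2)nn1)CC1CCCCC1`, differs from compound 1 at the other end of the molecule: benzylamino in place of cyclohexyl on a carbonyl carbon. Put another way, a cyclohexylcarbonyl becomes a benzylcarbamoyl. All three measured steps alter the amine side of the shared core, so none of them bears directly on this change on a carbonyl carbon, and the three measured numbers span only a modest range. Within the data shown here, with no guiding step, the expected step of a number 3 percentage points lower from compound 1 to compound 4 (within the scatter) from compound 1 to compound 4 is none beyond the scatter. Compound 4 is therefore estimated at 15%, within a range from 0% to 35%.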

Compound 4, a percentage reported as inhibition, at one concentration (the size of the read-out at that concentration, not a potency): 32%
Compound 4: the middle estimate sits 17 percentage points below what was measured; the range from low to high includes it.
By their numbers in this assay, from the lowest: compound 3; then compounds 2 and 1 (each within the scatter of the next); then compound 4.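

Within the data shown here, the step of a number 14 percentage points higher from compound 1 to compound 4 (beyond the scatter) shows that in this assay the number can also be moved from the carbonyl end of the molecule, whereas the earlier steps all changed the amine side and none was a rise. This one change does several things at once: the non-aromatic cyclohexyl ring gives way to the aromatic ring of benzylamino, and a nitrogen carrying one hydrogen-bond donor enters, turning cyclohexylcarbonyl into benzylcarbamoyl. Nothing available explains why the number moves with this change.

Which of these differences matters stays open: cyclohexylmethylamino on the same carbonyl carbon would keep the nitrogen without the aromatic ring, while a 2-phenylethyl group there would keep the aromatic ring without the nitrogen. Whether benzylcarbamoyl does the same alongside the dibutylamino group of compound 2 is also unknown.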